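Trimethoxyphenyl triazoles: aryl swap at the core

The compounds below may be only part of what the source reports. "The series", "measured", "known", "first", "only" and "open" are said of these compounds alone.

Measured in a functional assay on A549 cells (Homo sapiens) for antiproliferative activity, read by MTT assay, with a stated time of 72 h; a higher number here means a weaker inhibitor, a lower number a stronger inhibitor:
compound 1, `COc1cc(-n2ncnc2-c2ccccc2)cc(OC)c1OC`, gives > 10000 nM, a limit of this assay.
compound 2, `COc1cc(-n2ncnc2-c2ccc(Cl)cc2)cc(OC)c1OC`, gives > 10000 nM, likewise a limit.

Among the compounds with values here, compound 2 stands at the limit of this assay; the only further value shown is a limit as well, as the limit of > 10000 nM in this assay, at which 2 of the 2 values shown sit, records. The step that the two limits leave unreadable from compound 1 to compound 2 is therefore not readable. Compound 3, `COc1cccc(-c2ncnn2-c2cc(OC)c(OC)c(OC)c2)c1`, differs from compound 2 by 3-methoxyphenyl in place of 4-chlorophenyl on an aromatic carbon. Within the data shown here, no measured step covers this change, and the single step recorded is unreadable, so no direction beyond the scatter can be expected. Compound 3 is expected to sit at the limit too, the expected step being a step that the limit leaves unreadable from compound 2 to compound 3. The estimate for compound 3 is 20000 nM, between 8000 nM and 60000 nM.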

Compound 3, half-maximal inhibitory concentration: > 10000 nM
Compound 3 was reported as a limit; the forecaster's own chance of this, stated with the estimate: 80%; the middle value lies beyond the limit too.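

No step can be read among compound 1, compound 2 and compound 3, each reported only as a limit: the limit of > 10000 nM in this assay, at which 3 of the 3 values shown sit.

In this assay the compounds shown leave open which aryl group on the shared core, if any, gives a readable value.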